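This account rests on a few compounds, and the source may have more. Where it says the series, first, only, none or still open, it means among the compounds named here.

In a functional assay on 1321-N1 cells for agonist activity at Free fatty acid receptor 1 (Homo sapiens), read by calcium flux, with a stated time of 0.4 s (on this read-out higher numbers stand for an effect only at larger amounts of compound and lower numbers for an effect already at smaller amounts), compound 1, `C#Cc1ccc(CCC(=O)O)cc1`, reports only a limit, > 100000 nM. Compound 2, `O=C(O)CCc1ccc(C#CC2=CCCCC2)cc1`, gives 200 nM in this assay. Compound 3, `C=C(C)C#Cc1ccc(CCC(=O)O)c(F)c1`, gives 81.3 nM in this assay, the lowest of the two numbers shown. Among the compounds with values here, the sole measured step, an at least 500-fold lower number from compound 1 to compound 2 (2.69 log units; beyond the scatter), concerns the triple-bonded carbon, not the aromatic ring. Compound 4, `C=C(C)C#Cc1ccc(CCC(=O)O)cc1`, differs from compound 3 by hydrogen in place of fluoro on an aromatic carbon. Within the data shown here, no measured step bears on removal of the fluoro, so one expects in this assay a step no larger than the scatter, a 1.8-fold higher number from compound 3 to compound 4 (0.27 log units; within the scatter), if anything slightly upward. For compound 4 the estimate in this assay is 150 nM, expected between 50 nM and 450 nM.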

Compound 4, half-maximal effective concentration: 417 nM
The estimate for compound 4 lay 2.8-fold (0.44 log units) below the measured number; measured number inside the range.
By their numbers in this assay, from the lowest: compound 3; then compound 2; then compound 4. At a limit, above all of these: compound 1.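

In this assay, within the data shown here, the fluoro ortho to the 2-carboxyethyl group proves to matter, giving the first measured step at this aromatic carbon: a 5.1-fold higher number from compound 3 to compound 4 (0.71 log units; beyond the scatter). With hydrogen on that carbon, the group on the triple-bonded carbon also counts, though modestly: a 2.1-fold higher number from compound 2 to compound 4 (0.32 log units; beyond the scatter), while against the hydrogen there the gain stays large: an at least 230-fold lower number from compound 1 to compound 4 (2.37 log units; beyond the scatter). That last step rests on compound 1, which reports only a limit: the limit of > 100000 nM in this assay, at which 1 of the 4 values shown sits.

Nothing shown explains the effect of the fluoro. As far as these compounds go, whether chloro or methoxy on this aromatic carbon would match fluoro stays open.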